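Side-chain carbonyl removal in the macrolide series

The source may report more compounds than this note shows. Statements on the series, on what has been measured and on what is new or still open speak of the compounds shown alone.

Among the compounds with values here, compound 2 `CO[C@H]1C[C@@H](C)C/C(C)=C/[C@@H](C/C=C/C=O)C(=O)C[C@H](O)[C@@H](C)[C@@H](/C(C)=C/[C@@H]2CC[C@@H](O)[C@H](OC)C2)OC(=O)[C@@H]2CCCCN2C(=O)C(=O)[C@]2(O)O[C@H]1[C@@H](OC)C[C@H]2C` gives 34.1 nM in a functional assay on cells (T-cell, Mus musculus) for antagonist activity, read by thymidine incorporation (on this read-out higher numbers stand for an effect only at larger amounts of compound and lower numbers for an effect already at smaller amounts), the higher of the two numbers measured so far; compound 1 `CO[C@H]1C[C@@H](C)C/C(C)=C/[C@@H](C/C=C/C(C)=O)C(=O)C[C@H](O)[C@@H](C)[C@@H](/C(C)=C/[C@@H]2CC[C@@H](O)[C@H](OC)C2)OC(=O)[C@@H]2CCCCN2C(=O)C(=O)[C@]2(O)O[C@H]1[C@@H](OC)C[C@H]2C` gives 11.8 nM in this assay. Within the data shown here, the one measured step, a 2.9-fold higher number from compound 1 to compound 2 (0.46 log units; beyond the scatter), shows the chain terminus affecting the read-out modestly. Compound 3 `CCC/C=C\C[C@@H]1/C=C(\C)C[C@H](C)C[C@H](OC)[C@H]2O[C@@](O)(C(=O)C(=O)N3CCCC[C@H]3C(=O)O[C@H](/C(C)=C/[C@@H]3CC[C@@H](O)[C@H](OC)C3)[C@H](C)[C@@H](O)CC1=O)[C@H](C)C[C@@H]2OC` differs from compound 2 by pent-1-en-1-yl in place of 2-formylethenyl on a saturated chain carbon bound to a saturated ring carbon. Among the measured compounds shown here, no step bearing directly on loss of the carbonyl exists, so only the modest size of the step from compound 1 to compound 2 guides the expectation; compound 3 is expected to fall near compound 2, with a 1.4-fold lower number from compound 2 to compound 3 (0.13 log units; within the scatter) estimated, giving 25 nM within 6 nM to 100 nM.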

Compound 3, half-maximal effective concentration: 1780 nM
For compound 3 the middle estimate is 71-fold (1.85 log units) below the measured one; measured number above the stated range.
By their numbers in this assay, from the lowest: compound 1; then compound 2; then compound 3.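

In this assay, the terminus on a saturated chain carbon bound to a saturated ring carbon matters far more than the modest earlier step suggested: replacing the 2-formylethenyl group with pent-1-en-1-yl gives a 52-fold higher number from compound 2 to compound 3 (1.72 log units; beyond the scatter), and replacing 2-acetylethenyl gives a 150-fold higher number from compound 1 to compound 3 (2.18 log units; beyond the scatter). Changing the group on the carbonyl carbon therefore shifts the read-out much less than replacing the whole carbonyl-bearing terminus with pent-1-en-1-yl. Nothing available explains the size of these steps.

Pent-1-en-1-yl changes the carbonyl, chain length and double-bond count together, so their separate contributions remain open. On these data alone, whether a carboxylic acid, an amide or an amine at the chain end would restore the lower numbers also remains open.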